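Tert-butoxycarbonyl to methylcarbamoyl on the shared core

A few compounds are considered here, and "the series" means these few. Any claim that something is new, unique, unknown or untested is made for them only; others in the source may bear on it.

Two compounds carry the shared core with a nitro-methoxybenzyl thioether. Compound 1 `CCCCn1c(SCc2cc([N+](=O)[O-])ccc2OC)nc2cc(NC(=O)NC(C)(C)C)ccc21` gives 23 nM in an assay on isolated protein for inhibition of Gonadotropin-releasing hormone receptor (Homo sapiens); a lower number here means a stronger inhibitor, a higher number a weaker inhibitor. Compound 2 `COc1ccc([N+](=O)[O-])cc1CSc1nc2cc(NC(=O)OC(C)(C)C)ccc2n1C(C)C` gives 880 nM in this assay, the highest of the two numbers; its nearest neighbour is compound 1, which stands well beyond the scatter from it. Within the data shown here, no step between measured compounds that differ in a single place is available, so nothing measured tells how the group on the amide-type nitrogen alone changes the number.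

Compound 3 `CNC(=O)Nc1ccc2c(c1)nc(SCc1cc([N+](=O)[O-])ccc1OC)n2C(C)C` differs from compound 2 by methylamino in place of tert-butoxy on a carbonyl carbon. Among the measured compounds shown here, the only other compound with a (carbamoyl)amino arm, compound 1, also differs in the alkyl on the core nitrogen, so its low number cannot be assigned to that arm alone. Compound 3 is expected to fall below compound 2 by a moderate step, a 2.9-fold lower number from compound 2 to compound 3 (0.47 log units; beyond the scatter), with wide uncertainty. The estimate for compound 3 is 300 nM, within 60 nM to 1500 nM.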

Compound 3, half-maximal inhibitory concentration: 3300 nM
Beside the measured number, compound 3's estimate is 11-fold (1.04 log units) below it; measured number above the stated range.
By their numbers in this assay, from the lowest: compound 1; then compound 2; then compound 3.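

In this assay, among these compounds, methylamino in place of tert-butoxy on a carbonyl carbon gives a 3.8-fold higher number from compound 2 to compound 3 (0.57 log units; beyond the scatter) with the rest of the molecule unchanged, the first reading of this position on its own. The (methylcarbamoyl)amino arm therefore does not bring a lower number than the (tert-butoxycarbonyl)amino arm when the alkyl on the core nitrogen is the same, and the low number of compound 1 cannot be credited to the urea-type link alone. No supporting data bear on the reason for this step.

Still open, as far as these compounds go, is how the number moves with other groups on this carbonyl carbon, such as ethylamino, dimethylamino or methoxy. The separate contribution of the alkyl on the core nitrogen also remains unresolved, since compound 1 differs from compound 2 and compound 3 in more than one place.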